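The source may report more compounds than this note shows. Statements on the series, on what has been measured and on what is new or still open speak of the compounds shown alone.

Compound 1 `Cc1cc(-c2ccco2)cn2c(CSCCc3ccccc3)cnc12`: in an ADME assay on HEL cells (Homo sapiens) for cytotoxicity, with a stated time of 3 days (a higher number here means that more compound is tolerated, a lower number that less compound is tolerated), compound 1 gives > 4 ug/mL, which is a limit of the assay rather than a number.
Compound 2 `Cc1cc(-n2ccc3cccnc32)cn2c(CSCCc3ccccc3)cnc12`: compound 2 gives 20 ug/mL.
Compound 3 `Cc1cc(-c2ccoc2)c2ncc(CSCCc3ccccc3)n2c1`: compound 3 gives 100 ug/mL.

Compound 3 thus holds the higher of the two numbers, with compound 2 nearest and separated from it by a gap beyond the scatter. The unmeasured compound 4 `Cc1cc(Sc2ccc(O)cc2)c2ncc(CSCCc3ccccc3)n2c1` differs from compound 3 by (4-hydroxyphenyl)sulfanyl in place of furan-3-yl on an aromatic carbon. Going by the values given here, only one measured step bears on this change: a step that the limit leaves unreadable from compound 1 to compound 2, and its size cannot be read because of the limit of > 4 ug/mL in this assay, at which 1 of the 3 values shown sits. Among the compounds with values here, no measured step therefore sets the size or direction to expect. Compound 4 is estimated at 50 ug/mL, with a range from 15 ug/mL to 100 ug/mL. The expected step, a 2.0-fold lower number from compound 3 to compound 4 (0.30 log units; within the scatter), is a modest fall that stays near the scatter.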

Compound 4, minimum cytotoxic concentration: > 100 ug/mL
Compound 4 was reported as a limit; the forecaster's own chance of this, stated with the estimate: 25%; middle value at least 2.0-fold (0.30 log units) from the limit.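

In this assay compound 4 gives > 100 ug/mL, which is a limit of the assay and not a number. Going by these compounds alone, the change at this aromatic carbon therefore has a direction, which the earlier compounds did not give: a number no lower from compound 3 to compound 4 (the limit leaves the size open). So (4-hydroxyphenyl)sulfanyl, with its one six-membered aromatic ring of carbon only, is tolerated here at least as well as furan-3-yl.

The compounds shown leave open how large the step is, and whether the hydroxy group or the sulfur matters to it. They also leave open how an amine or a carboxylic acid on the phenyl ring would read at this position.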